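The compounds below may be only part of what the source reports. "The series", "measured", "known", "first", "only" and "open" are said of these compounds alone.

Three compounds share one core and differ only in what sits on the amide-type nitrogen. Compound 1 `Cc1ccc(OCC(=O)N(Cc2cccs2)CC(C)C)cc1` gives 900 nM in an assay on HEK293 cells for agonist activity at transient receptor potential cation channel subfamily M member 8 (Homo sapiens), read by fluorescence and calcium flux, with a stated time of 15 min (a higher number here means that more compound is needed for the effect, a lower number that less compound is needed), compound 2 `C=CCN(Cc1cccs1)C(=O)COc1ccc(C)cc1` gives 20 nM, and compound 3 `Cc1ccc(OCC(=O)N(Cc2cccs2)c2ccon2)cc1` gives 2 nM, the lowest of the three numbers. The steps of a 450-fold lower number from compound 1 to compound 3 (2.65 log units; beyond the scatter) and a 10-fold lower number from compound 2 to compound 3 (1.00 log units; beyond the scatter) both run from a chain group to a five-membered aromatic ring. Going by the values given here, compound 4 `Cc1ccc(OCC(=O)N(Cc2cccs2)c2ccccc2)cc1` carries phenyl in place of 1,2-oxazol-3-yl on an amide-type nitrogen, so again an aromatic ring stands on that nitrogen, but no measured pair shows one ring exchanged for another. Compound 4 is therefore expected to stay near the ring-bearing compound 3, with a step of a 2.5-fold higher number from compound 3 to compound 4 (0.40 log units; beyond the scatter) in this assay, and is estimated at 5 nM, within 1.5 nM to 20 nM.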

Compound 4, half-maximal effective concentration: 23 nM
Beside the measured number, compound 4's estimate is 4.6-fold (0.66 log units) below it; the whole stated range lies below it.
By their numbers in this assay, from the lowest: compound 3; then compounds 2 and 4 (each within the scatter of the next); then compound 1.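

On the amide-type nitrogen, an aromatic ring alone does not bring the low number of compound 3, since phenyl in place of 1,2-oxazol-3-yl gives a clear rise in this assay (a 12-fold higher number from compound 3 to compound 4 (1.06 log units; beyond the scatter)). Phenyl cannot be told apart from allyl here (a 1.2-fold higher number from compound 2 to compound 4 (0.06 log units; within the scatter)), although the step from isobutyl remains large (a 39-fold lower number from compound 1 to compound 4 (1.59 log units; beyond the scatter)), so which ring stands at this position matters. Nothing available explains the gap between these two rings. The compounds shown leave open whether the ring nitrogen, the ring oxygen or the ring size goes with the lower number. They also leave open where a pyridyl or a furanyl group would fall at this nitrogen.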